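Series notes: dropping one methoxy group from compound 2

The source may hold more compounds than are shown below. What is called first, only, known or untested is meant among the compounds shown, and "the series" means these compounds.

Compound 2 `COc1ccc(-n2cnc3cnc(-c4ccc(F)cc4C)cc32)cc1OC` is the reference point for this step. In an ADME assay on S9 fraction from liver (Mus musculus) for metabolic stability, read by LC-MS, using NADPH, with a stated time of 45 min, tested at 3 uM, in the presence of a further agent that is not named here (on this read-out lower numbers stand for lower hepatic extraction and higher numbers for higher hepatic extraction), compound 2 gives 1. Compound 1 `COc1ccc(-n2cnc3cnc(-c4ccccc4)cc32)cc1OC` gives 1 in this assay, and compound 3 `COc1ccc(-n2cnc3cnc(-c4ccc(F)cc4OC)cc32)cc1OC` gives 1. Compound 2 stands level with both neighbours: the step of no change at the digits printed from compound 1 to compound 2 (within the scatter) and the step of no change at the digits printed from compound 2 to compound 3 (within the scatter) lie within the scatter, as does the step of no change at the digits printed from compound 1 to compound 3 (within the scatter). All three measured values sit at the upper end of the read-out.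

Compound 4 `COc1ccc(-n2cnc3cnc(-c4ccc(F)cc4C)cc32)cc1` differs from compound 2 by hydrogen in place of methoxy on an aromatic carbon. Among the measured compounds shown here, none of the measured steps touches this part of the structure; the known steps all concern the phenyl group of compound 1 and its replacements, and each of them is within the scatter. They show that those changes leave the read-out where it was, but they give no direct guidance on the change made here. For compound 4 the step a number 0.050 lower from compound 2 to compound 4 (within the scatter) is therefore expected to stay within the scatter. Compound 4 is estimated at 0.95, with a range from 0.8 to 1.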

Compound 4, hepatic extraction ratio: 1
Estimate against measurement, compound 4: 0.050 below, within the range that was stated.
By their numbers in this assay, from the lowest: compounds 1, 2, 3 and 4 (each within the scatter of the next).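

In this assay, among the compounds shown here, the step of no change at the digits printed from compound 2 to compound 4 (within the scatter) gives the first reading at this position: hydrogen in place of methoxy, on the aromatic carbon ortho to a methoxy group and meta to a large group, leaves the read-out where it stood. The earlier steps shown here touched only the phenyl group of compound 1 and its replacements, so the dimethoxy-substituted side of compound 2 now has one change read as well, and it too stays within the scatter. Nothing measured here bears on why this position tolerates the loss of the methoxy group.

All four compounds stand level, so none of the changes shown yet moves this read-out. Open, going by these compounds, is whether the remaining methoxy group can be replaced in the same way, and whether an amine, a carboxylic acid or a longer chain such as butoxy on this carbon would shift the hepatic extraction ratio from the level of compound 4 at 1.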